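This account rests on a few compounds, and the source may have more. Where it says the series, first, only, none or still open, it means among the compounds named here.

Measured compounds:
compound 1 `O=C1COc2ccc(-c3cnc(Cl)c(NS(=O)(=O)c4ccc(F)cc4)c3)cc2N1c1ccc(Cl)cc1`: 27900 nM
compound 2 `O=C1COc2ccc(-c3cnc(Cl)c(NS(=O)(=O)c4ccc(F)cc4)c3)cc2N1c1ccccc1`: 39800 nM
compound 3 `O=C1COc2ccc(-c3cnc4ccccc4c3)cc2N1c1ccc(Cl)cc1`: 36100 nM

All three values come from a functional assay on HCT-116 cells (Homo sapiens) for antiproliferative activity, read by MTT assay, with a stated time of 72 h; a lower number here means a stronger inhibitor, a higher number a weaker inhibitor. Compound 1 and compound 2 differ by hydrogen in place of chloro on an aromatic carbon; that change gives a 1.4-fold higher number from compound 1 to compound 2 (0.15 log units; within the scatter). Compound 3 carries a different core; the difference between the two cores is not broken down here. Compound 3 and compound 2 lie within the scatter of each other, as do compound 3 and compound 1, so nothing separates the three.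

Compound 4 `O=C1COc2ccc(-c3cnc4ccccc4c3)cc2N1c1ccccc1` is not yet measured. It differs from compound 3 by hydrogen in place of chloro on an aromatic carbon, the same change as between compound 1 and compound 2. The expectation rests on that earlier step, a 1.4-fold higher number from compound 1 to compound 2 (0.15 log units; within the scatter), which stayed within the scatter; on the core of compound 3 a similarly small move is expected, a 1.2-fold higher number from compound 3 to compound 4 (0.10 log units; within the scatter). Compound 4 is accordingly estimated at 45000 nM, expected to fall between 20000 nM and 100000 nM.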

Compound 4, half-maximal inhibitory concentration: > 40000 nM
Compound 4: a limit, no number; the forecaster's own chance of this, stated with the estimate: 20%; the middle value does not contradict the limit.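

In this assay compound 4 gives > 40000 nM, which is a limit of the assay and not a number. The change from 4-chlorophenyl to phenyl on the second core therefore reads only as a floor: an at least 1.1-fold higher number from compound 3 to compound 4 (0.04 log units; that floor lies within the scatter). This shows no step beyond the scatter on either core, but it does not show that the change has the same size on both, since the true value of compound 4 remains unknown: the same change on two cores in this assay, a 1.4-fold higher number (0.15 log units; within the scatter) from compound 1 to compound 2 and an at least 1.1-fold higher number (0.04 log units; that floor lies within the scatter) from compound 3 to compound 4; the limit leaves it open whether they differ

The compounds shown leave open whether another group in place of the chloro, such as an amine or a carboxylic acid, would give a step beyond the scatter on either core. From the compounds shown here alone, the true size of the step to compound 4 also remains open.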